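The compounds below may be only part of what the source reports. "The series", "measured", "known", "first", "only" and "open" are said of these compounds alone.

Measured compounds:
Compound 1, `CCN1CCc2c(sc(NC(=O)Nc3ccc(Br)cc3)c2C(N)=O)C1`: 3130 nM
Compound 2, `CCN1CCc2c(sc(NC(=O)c3ccccc3)c2C(N)=O)C1`: > 25000 nM, a limit of the assay
Compound 3, `CCN1CCc2c(sc(NC=O)c2C(N)=O)C1`: > 25000 nM, a limit of the assay

Among the compounds with values here, in a functional assay (strain AB) with Danio rerio as the target, read by microscopy, with a stated time of 1 h (on this read-out higher numbers stand for an effect only at larger amounts of compound and lower numbers for an effect already at smaller amounts), compound 1 gives 3130 nM, and that is the only number among the three. Compound 2 reaches only > 25000 nM, which is a limit of the assay and not a number. Compound 3 likewise stops at > 25000 nM, again a limit (the limit of > 25000 nM in this assay, at which 2 of the 3 values shown sit). The two measured steps are therefore an at least 7.9-fold higher number from compound 1 to compound 2 (0.90 log units; beyond the scatter) and an at least 7.9-fold higher number from compound 1 to compound 3 (0.90 log units; beyond the scatter): taking the (4-bromophenyl)amino away from the carbonyl carbon costs a great deal.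

Compound 4, `CCN1CCc2c(sc(NC(=O)NCc3cccc(Cl)c3)c2C(N)=O)C1`, is not yet measured. It keeps the whole urea of compound 1 and changes only the aryl part: 3-chlorobenzyl in place of 4-bromophenyl on an amide-type nitrogen. Within the data shown here, no measured step touches that aryl alone, so the two large losses above do not bear on it directly; they only show that the group on this nitrogen matters. A smaller step is expected, most likely a modest loss. The estimate for compound 4 in this assay is 5000 nM, with a range from 1500 nM to 20000 nM, which means an expected step of a 1.6-fold higher number from compound 1 to compound 4 (0.20 log units; within the scatter).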

Compound 4, half-maximal effective concentration: > 25000 nM
Compound 4: no number, only a limit; the forecaster's own chance of this, stated with the estimate: 15%; at least 5.0-fold (0.69 log units) between middle value and limit.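

In this assay keeping the urea of compound 1 is not enough to hold the effect: putting 3-chlorobenzyl in place of 4-bromophenyl on an amide-type nitrogen gives an at least 7.9-fold higher number from compound 1 to compound 4 (0.90 log units; beyond the scatter) through this one change. The earlier losses came from taking the whole (4-bromophenyl)amino group off the carbonyl carbon, so they could not separate the urea from the aryl group it carries; compound 4 shows that the urea alone does not preserve the effect and that the group on this nitrogen matters as well. Compound 4 stands at > 25000 nM and that is a limit of the assay, not a number.

As far as these compounds go, the change swaps several things together, so it remains open whether the loss follows from the benzyl link or from the chlorine in place of bromine; a 3-chlorophenyl or a 4-bromobenzyl group on this nitrogen would help separate these. How far compound 4 lies from compounds 2 and 3 cannot be read, because all three stop at one and the same limit: the limit of > 25000 nM in this assay, at which 3 of the 4 values shown sit.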